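Series notes: a smaller group at the aromatic carbon

The source may report more compounds than this note shows. Statements on the series, on what has been measured and on what is new or still open speak of the compounds shown alone.

Measured so far:
- Compound 1, `CCOC(=O)N1C[C@@H]2C[C@H]1CN2c1nc(-c2cnc(N)c(OC(F)F)n2)cc(N2CC3CC2C3)n1`, in an assay on Sf21 cells for inhibition of mitogen-activated protein kinase kinase kinase 13 (Homo sapiens), read by HTRF, with a stated time of 1.5 h (on this read-out lower numbers stand for stronger inhibition and higher numbers for weaker inhibition), gives 13 nM.
- Compound 2, `Nc1ncc(-c2cc([C@@H]3CCCO3)nc(N3C[C@@H]4C[C@H]3CO4)n2)nc1OC(F)F`, in this assay gives 23 nM.

For the measured compounds named here, only two numbers are known. Compound 2 carries the higher of the two; the nearest is compound 1, whose number is lower, but that gap lies within the usual scatter of repeated measurements, so no order between compound 1 and compound 2 can be read from it. Going by the values given here, no pair of measured compounds differs in a single place, so no measured step is available to lean on.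

Compound 3, `CSc1cc(-c2cnc(N)c(OC(F)F)n2)nc(N2C[C@@H]3C[C@H]2CO3)n1`, is the next point. Relative to compound 2 the change is methylsulfanyl in place of oxolan-2-yl on an aromatic carbon. The group that enters is much smaller than the one that leaves, and the oxolan-2-yl ring with its defined stereocentre is gone.

Among the compounds with values here, with no measured step to guide it, the expected change from compound 2 to compound 3 is a 2.0-fold higher number from compound 2 to compound 3 (0.29 log units; within the scatter), a modest move toward a weaker number, probably not far beyond the scatter. Compound 3 is therefore expected to give about 45 nM, estimated between 15 nM and 140 nM.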

Compound 3, half-maximal inhibitory concentration: 45 nM
For compound 3 middle estimate and measured number coincide at the digits printed; low and high end bracket the measured number.
By their numbers in this assay, from the lowest: compounds 1, 2 and 3 (each within the scatter of the next, the first and the last beyond it).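

In this assay, for the compounds shown here, the first single-place step reads a 2.0-fold higher number from compound 2 to compound 3 (0.29 log units; within the scatter), so on this aromatic carbon, opposite the ring nitrogen, methylsulfanyl and oxolan-2-yl cannot be told apart. The position therefore tolerates the loss of the ring and its defined stereocentre, and a group of 2 heavy atoms serves here as well as one of 5 within the resolution of the read-out, with compound 3 at 45 nM. No measurement is at hand that would explain this result.

What the compounds shown leave open is how far this tolerance extends on the same carbon, for example to an amine, a carboxylic acid or a longer chain such as butylsulfanyl, or to the opposite stereocentre of the oxolan-2-yl ring. Also open, from the compounds shown here alone, is whether the same exchange would read the same way with the other groups of compound 1 in place, since a single step on one background cannot show this.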